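The source may report more compounds than this note shows. Statements on the series, on what has been measured and on what is new or still open speak of the compounds shown alone.

Measured compounds in a functional assay on HCT-116 cells (Homo sapiens) for inhibition, read by MTT assay, with a stated time of 72 h; a higher number here means a weaker inhibitor of growth, a lower number a stronger inhibitor of growth:
- compound 1, `CNC(=O)CCc1ccncc1-c1ccc2ccccc2c1`: 19300 nM
- compound 2, `COC(=O)/C=C/c1ccncc1-c1ccc2ccccc2c1`: 350 nM
- compound 3, `O=C(O)COc1ccncc1-c1ccc2ccccc2c1`: "not determined" (no result reported)

Compound 3 stands nowhere on the numbers: in this assay compound 3 has no result, so the step to compound 4, `O=C(/C=C/c1ccncc1-c1ccc2ccccc2c1)NC1CC1`, has no measured starting point. The change is 2-(cyclopropylcarbamoyl)ethenyl in place of carboxymethoxy on an aromatic carbon. Among the compounds with values here, the only measured step, a 55-fold lower number from compound 1 to compound 2 (1.74 log units; beyond the scatter), is the one that bears on it, since it also introduces an ethenyl side chain with a carbonyl on the same aromatic carbon; compound 4 shares the ethenyl with compound 2 but carries a cyclopropylcarbamoyl rather than a methoxycarbonyl, and compound 1 is the sole amide measured. Compound 4 is therefore expected to lie nearer compound 2 than compound 1, with wide uncertainty, estimated at 1200 nM (range 250 nM to 6000 nM).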

Compound 4, concentration for 50% growth inhibition: 6180 nM
Compound 4: the middle estimate sits 5.2-fold (0.71 log units) below what was measured; measured number above the stated range.
By their numbers in this assay, from the lowest: compound 2; then compound 4; then compound 1.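

In this assay the side chain on the aromatic carbon opposite the ring nitrogen proves sensitive at its carbonyl carbon, where cyclopropylamino in place of methoxy gives an 18-fold higher number from compound 2 to compound 4 (1.25 log units; beyond the scatter) and removes most of the advantage compound 2 holds. Between the two amide side chains the gap is smaller, at a 3.1-fold lower number from compound 1 to compound 4 (0.49 log units; beyond the scatter) for the 2-(cyclopropylcarbamoyl)ethenyl group. No evidence available here accounts for either step.

A 2-(methoxycarbonyl)ethyl group would separate the ethenyl contribution from that of the ester. A carboxylic acid or a methylamino group on the ethenyl carbonyl would show whether the ester itself is what matters.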